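This account rests on a few compounds, and the source may have more. Where it says the series, first, only, none or still open, it means among the compounds named here.

Three compounds share one core and differ only in the aromatic ring attached to an aromatic carbon of the five-membered ring. Compound 1 `COc1cc(OC)cc(N2CCN(C(=O)c3onc(C)c3-c3ccccc3)CC2)c1` gives 152 nM in a functional assay on HL-60 cells (Homo sapiens) for inhibition, read by MTT assay, with a stated time of 72 h; a lower number here means a stronger inhibitor, a higher number a weaker inhibitor. Compound 2 `COc1cc(OC)cc(N2CCN(C(=O)c3onc(C)c3-c3cccc(F)c3)CC2)c1` gives 152 nM, and compound 3 `COc1cc(OC)cc(N2CCN(C(=O)c3onc(C)c3-c3ccc(F)cc3)CC2)c1` gives 475 nM. Compound 3 thus has the highest number of the three: from compound 1 to compound 3 the step is a 3.1-fold higher number from compound 1 to compound 3 (0.49 log units; beyond the scatter), and from compound 2 to compound 3 it is a 3.1-fold higher number from compound 2 to compound 3 (0.49 log units; beyond the scatter), while from compound 1 to compound 2 there is no change at the digits printed from compound 1 to compound 2 (within the scatter).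

Compound 4 `COc1cc(OC)cc(N2CCN(C(=O)c3onc(C)c3-c3ccccc3F)CC2)c1` is not yet measured. Its difference from compound 3 is 2-fluorophenyl in place of 4-fluorophenyl on an aromatic carbon. Among the compounds with values here, the step that bears most directly on it is the one from compound 2 to compound 3, where moving the fluorine from one aromatic carbon to another produced a modest change, and the step from compound 1 to compound 2, where adding fluorine changed nothing. With only these two placements known, the third placement cannot be predicted closely, but the range spanned so far is narrow, and compound 4 is expected to fall within it, giving an estimated step of a 2.1-fold lower number from compound 3 to compound 4 (0.31 log units; beyond the scatter). The estimate for compound 4 is 230 nM, with a range from 90 nM to 600 nM.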

Compound 4, half-maximal inhibitory concentration: 165 nM
Compound 4: the middle estimate sits 1.4-fold (0.14 log units) above what was measured; low and high end bracket the measured number.
By their numbers in this assay, from the lowest: compounds 1, 2 and 4 (each within the scatter of the next); then compound 3.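

In this assay, putting 2-fluorophenyl in place of 4-fluorophenyl on the aromatic carbon of the five-membered ring gives a 2.9-fold lower number from compound 3 to compound 4 (0.46 log units; beyond the scatter) and so returns to the level of the other two compounds. The 2-fluorophenyl group cannot be told apart from 3-fluorophenyl, with a 1.1-fold higher number from compound 2 to compound 4 (0.04 log units; within the scatter) within the usual scatter, or from the plain phenyl ring, with a 1.1-fold higher number from compound 1 to compound 4 (0.04 log units; within the scatter) likewise within the scatter. Among the three placements of one fluorine on this ring, only the 4-fluorophenyl group of compound 3 stands apart from the compound without fluorine, so the placement matters here and the mere presence of fluorine does not; nothing in the available data explains why this placement alone differs.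

Going by these compounds, the aromatic ring in these compounds carries only hydrogen or a single fluorine, so it stays open whether the higher number of compound 3 is specific to fluorine or would also appear with a chlorine or a methoxy group at that place on the ring. On these data alone, it also stays open how a ring bearing an amine or a carboxylic acid, or two fluorines, would fare.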